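A few compounds are considered here, and "the series" means these few. Any claim that something is new, unique, unknown or untested is made for them only; others in the source may bear on it.

Measured so far:
compound 1, `Nc1scc(CN2CCN(c3cccc(C(F)(F)F)c3)CC2)c1C(=O)c1ccc(Cl)cc1`: -30%
compound 2, `Nc1scc(CN2CCN(CCCc3ccc(Cl)cc3)CC2)c1C(=O)c1ccc(Cl)cc1`: -3%

Both compounds were run in a functional assay on CHO cells with adenosine receptor A1 (Homo sapiens) as the target, read by cAMP accumulation and immunoassay, with a stated time of 6 min, tested at 0.1 uM; on this read-out higher numbers stand for a weaker effect at the one concentration tested and lower numbers for a stronger effect. Compound 2 holds the highest of the two numbers; its nearest neighbour is compound 1, whose value stands lower by a step beyond the scatter. For the measured compounds named here, the one step measured within the pair, a number 27 percentage points higher from compound 1 to compound 2 (beyond the scatter), is the only comparison on hand, and it describes an exchange of an aryl group for a 3-(4-chlorophenyl)propyl chain on an amine nitrogen in a ring, read at the single concentration.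

Compound 3, `Nc1scc(CN2CCN(c3ccc(Cl)c(Cl)c3)CC2)c1C(=O)c1ccc(Cl)cc1`, is not yet measured. Its change from compound 2 is 3,4-dichlorophenyl in place of 3-(4-chlorophenyl)propyl on an amine nitrogen in a ring. This reverses the sense of the measured step: the chain leaves and an aryl group returns to the same amine nitrogen in a ring, so the expectation rests on compound 1 having given -30%. The move is expected to run in the opposite direction to the measured step and of roughly comparable size, so the estimated step is a number 22 percentage points lower from compound 2 to compound 3 (beyond the scatter). Compound 3 is therefore expected to give about -25% in this assay, with a range from -45% to 0%.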

Compound 3, a percentage reported as activity, at one concentration (the size of the read-out at that concentration, not a potency): -13%
The estimate for compound 3 lay 12 percentage points below the measured number; the measured number falls inside the stated range.
By their numbers in this assay, from the lowest: compound 1; then compounds 3 and 2 (each within the scatter of the next).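

In this assay the exchange of the chain for an aryl group gives a number 10 percentage points lower from compound 2 to compound 3 (within the scatter) and so leaves 3,4-dichlorophenyl and 3-(4-chlorophenyl)propyl on this amine nitrogen in a ring indistinguishable at the single concentration. The two aryl groups, by contrast, do separate, with a number 17 percentage points higher from compound 1 to compound 3 (beyond the scatter) as the exchange of 3-(trifluoromethyl)phenyl for 3,4-dichlorophenyl. Among these three compounds, then, an aryl group on this nitrogen does not by itself go with the lowest number, and compound 3 goes against any reading of aryl versus chain as the deciding difference, since the substituents on the aryl ring also change the read-out at this position. No measurement on hand offers an explanation for either step.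

The compounds shown leave open whether the number of compound 1 belongs to the trifluoromethyl group itself or to the substitution pattern of its ring, a question that plain phenyl, 3-chlorophenyl or 4-(trifluoromethyl)phenyl on the same nitrogen would address. They also leave open how the length of the chain matters, which a benzyl group or a longer chain carrying the same 4-chlorophenyl ring would test, and whether these differences hold beyond the one concentration tested.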